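The source may hold more compounds than are shown below. What is called first, only, known or untested is meant among the compounds shown, and "the series" means these compounds.

Measured so far in a functional assay on SF-268 cells (Homo sapiens) for inhibition, read by sulforhodamine B assay, with a stated time of 48 h, tested at 10 uM (on this read-out lower numbers stand for less inhibition of growth and higher numbers for more inhibition of growth at the one concentration tested), are two compounds:
- compound 1 `C/C(=N\O)c1ccc(NC(=O)Cn2nc(-c3ccc(Cl)cc3)nc2N)cc1` gives 10.5% in this test
- compound 2 `COc1ccc(-c2nc3sc(-c4ccccc4)cn3n2)cc1` gives 28% in this test

Compound 2 stands highest of these two numbers, and the gap down to compound 1 lies beyond the scatter. Neither number is large, so growth of these cells is only partly held back at the one concentration tested.

Compound 3 (`c1ccc(-c2nc3sc(-c4ccccc4)cn3n2)cc1`) keeps the core of compound 2 and differs from it in one place. The change is hydrogen in place of methoxy on an aromatic carbon, para to a large group.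

For the measured compounds named here, no two measured compounds differ in one place, so the data give no direct guide to this change. Compound 1 is too different in structure to help. The expectation therefore starts from compound 2 at 28% and allows for movement in either direction, leaning slightly downward. The expected change, a number 5 percentage points lower from compound 2 to compound 3 (within the scatter) as estimated, is a small fall that probably stays within the scatter of this assay as a read-out. For compound 3 the estimate is 23% with an expected range from 8% to 40% when it is measured.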

Compound 3, percent growth inhibition at one concentration: 7%
Estimate against measurement, compound 3: 16 percentage points above; the measured number lies below the stated range.
By their numbers in this assay, from the lowest: compounds 3 and 1 (each within the scatter of the next); then compound 2.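

In this assay, hydrogen in place of methoxy on an aromatic carbon, para to a large group, gives a number 21 percentage points lower from compound 2 to compound 3 (beyond the scatter), so what this place carries matters to the read-out on the shared core. For the compounds shown here, this is the first comparison between compounds that differ in one place, and it ties the higher number of compound 2 to the presence of the methoxy group, which brings 2 heavy atoms and 1 hydrogen-bond acceptor that hydrogen does not. No measurement shown here explains what it is about the methoxy group that accounts for this step.

With only methoxy and hydrogen shown at this place, it remains open whether an ethoxy group, a hydroxyl group, a fluorine atom or an amine would keep the number near that of compound 2, exceed it or leave it near that of compound 3. Also open, as far as these compounds go, is whether the same exchange would give a step of similar size on the other benzene ring of the shared core, or at other concentrations and in other cell lines.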